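Nitro for chloro in the shared core series

This account rests on a few compounds, and the source may have more. Where it says the series, first, only, none or still open, it means among the compounds named here.

The series shares the core of compound 1 `CCn1c(/C=C2/C(=O)Nc3ccccc32)nc2ccccc21`. In a functional assay on HGC cells (Homo sapiens) for cytotoxicity, read by MTT assay, with a stated time of 48 h (a higher number here means a weaker inhibitor, a lower number a stronger inhibitor), compound 1 gives only a limit of the assay, > 50000 nM. Compound 3 `CCn1c(/C=C2/C(=O)Nc3ccc(Cl)cc32)nc2ccccc21` carries chloro in place of hydrogen on an aromatic carbon of that core. In this assay compound 3 likewise gives only a limit, > 50000 nM. The step that the two limits leave unreadable from compound 1 to compound 3 is therefore unreadable because both ends sit at the limit of > 50000 nM in this assay, at which 2 of the 3 values shown sit. The related compound 2 `Cn1c(/C=C2/C(=O)Nc3ccc([N+](=O)[O-])cc32)nc2ccccc21`, which carries nitro, has in this assay "not determined" (no result reported). So compound 3 stands at the limit, with no number to place it among the others.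

Compound 4 `CCn1c(/C=C2/C(=O)Nc3ccc([N+](=O)[O-])cc32)nc2ccccc21` differs from compound 3 by nitro in place of chloro on an aromatic carbon. Among the compounds with values here, the only measured step that bears on this position, from hydrogen to chloro, has no readable size, so no direction beyond the scatter can be expected for the change to nitro. Compound 4 is expected to give an estimated 60000 nM, within 20000 nM to 200000 nM, most probably again reported as a limit. The expected step is estimated as a step that the limit leaves unreadable from compound 3 to compound 4.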

Compound 4, half-maximal inhibitory concentration: > 50000 nM
Compound 4: a limit, no number; the forecaster's own chance of this, stated with the estimate: 75%; the middle value is on the limit's open side.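

Compound 4, like compound 1 and compound 3, gives only a limit, so no step among these three can be read in this assay for this reason: the limit of > 50000 nM in this assay, at which 3 of the 4 values shown sit.

The compounds shown leave open whether hydrogen, chloro and nitro on this aromatic carbon differ at all in this assay on the shared core.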